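This account rests on a few compounds, and the source may have more. Where it says the series, first, only, none or still open, it means among the compounds named here.

Compound 1 `CC1=C/C(=C\C(C)C)C(=O)C(C)(O)C12CC2` belongs to a set of analogues that share one core and differ only in the group on a double-bonded chain carbon bound to a double-bonded ring carbon. In a functional assay on SW480 cells (Homo sapiens) for antiproliferative activity (on this read-out higher numbers stand for weaker inhibition and lower numbers for stronger inhibition), compound 1 gives 30 nM. Compound 3 `CC1=C/C(=C\Cl)C(=O)C(C)(O)C12CC2`, carrying chloro there, gives 30 nM in this assay, so compound 1 stands level with compound 3, and the step of no change at the digits printed from compound 1 to compound 3 (within the scatter) lies within the scatter. Compound 2 `CC1=C/C(=C\c2cccs2)C(=O)C(C)(O)C12CC2`, carrying thiophen-2-yl, gives > 10000 nM, which is the limit of > 10000 nM in this assay, at which 1 of the 3 values shown sits, and not a number. The step of an at least 330-fold higher number from compound 1 to compound 2 (2.52 log units; beyond the scatter) is large. Compound 4 `C=C/C=C1\C=C(C)C2(CC2)C(C)(O)C1=O` is not yet measured; it differs from compound 1 thus: vinyl in place of isopropyl on a double-bonded chain carbon bound to a double-bonded ring carbon. Vinyl, like chloro, brings no ring, whereas thiophen-2-yl does, so a step within the scatter is expected, no change at the digits printed from compound 1 to compound 4 (within the scatter). Compound 4 is therefore estimated at 30 nM, between 10 nM and 100 nM.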

Compound 4, half-maximal inhibitory concentration: 180 nM
Compound 4: the middle estimate sits 6.0-fold (0.78 log units) below what was measured; measured number outside the range, above it.
By their numbers in this assay, from the lowest: compounds 1 and 3 (each within the scatter of the next); then compound 4. At a limit, above all of these: compound 2.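

Lacking a ring is not enough to keep a group level at this position: the change to vinyl brings a 6.0-fold higher number from compound 1 to compound 4 (0.78 log units; beyond the scatter), and likewise a 6.0-fold higher number from compound 3 to compound 4 (0.78 log units; beyond the scatter), so the match between isopropyl and chloro does not extend to every ringless group. The loss remains much smaller than with thiophen-2-yl, as vinyl shows an at least 55-fold lower number from compound 2 to compound 4 (1.74 log units; beyond the scatter). Compound 2 stands at a limit, not a number: the limit of > 10000 nM in this assay, at which 1 of the 4 values shown sits.

As far as these compounds go, it remains open whether a longer chain such as n-butyl, or an amine, would stay level with isopropyl and chloro. From the compounds shown here alone, it is also open whether another ring, such as phenyl, would reach that limit too.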